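The source may report more compounds than this note shows. Statements on the series, on what has been measured and on what is new or still open speak of the compounds shown alone.

Measured compounds: compound 1 `O=C1Nc2ccc(S(=O)(=O)N3CCOCC3)cc2/C1=N/NS(=O)(=O)c1ccccc1` gives 302000 nM in an ADME assay on WI-38 cells (Homo sapiens) for cytotoxicity, read by sulforhodamine B assay, with a stated time of 24 h; a higher number here means a weaker inhibitor, a lower number a stronger inhibitor; compound 2 `O=C1Nc2ccc(S(=O)(=O)N3CCOCC3)cc2/C1=N/c1ccc(O)cc1` gives 259000 nM; compound 3 `O=C1Nc2ccc(S(=O)(=O)N3CCOCC3)cc2/C1=N/c1ccc(Cl)cc1` gives 468000 nM.

Compound 3 has the highest of the three numbers, yet the steps of a 1.5-fold higher number from compound 1 to compound 3 (0.19 log units; within the scatter) and a 1.8-fold higher number from compound 2 to compound 3 (0.26 log units; within the scatter) both lie within the scatter, so the three compounds cannot be told apart on these data. Compound 4 `CC(=O)N/N=C1\C(=O)Nc2ccc(S(=O)(=O)N3CCOCC3)cc21` has not yet been measured. It differs from compound 3 in one place: acetamido in place of 4-chlorophenyl on a double-bonded nitrogen. The acetamido group, like the (phenylsulfonyl)amino group of compound 1, brings a hydrogen-bond donor and an acceptor onto the double-bonded nitrogen, where compound 3 carries an aromatic ring. The two measured steps that touch this position, from compound 1 to compound 3 and from compound 2 to compound 3, were both within the scatter, and all three measured compounds sit close together. The expectation is therefore a step of no more than the scatter in this assay, with no clear direction, shown as a 1.5-fold lower number from compound 3 to compound 4 (0.17 log units; within the scatter). Compound 4 is estimated at 320000 nM, within the range 150000 nM to 700000 nM.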

Compound 4, half-maximal inhibitory concentration: 325000 nM
Beside the measured number, compound 4's estimate is 1.0-fold (0.01 log units) below it, and the stated range covers the measured number.
By their numbers in this assay, from the lowest: compounds 2, 1, 4 and 3 (each within the scatter of the next).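

In this assay the double-bonded nitrogen now carries a group with no ring, and the number barely responds: acetamido in place of 4-chlorophenyl gives a 1.4-fold lower number from compound 3 to compound 4 (0.16 log units; within the scatter) and stays within the scatter, as does acetamido in place of 4-hydroxyphenyl, which gives a 1.3-fold higher number from compound 2 to compound 4 (0.10 log units; within the scatter) here. Acetyl in place of phenylsulfonyl on an amine nitrogen gives a 1.1-fold higher number from compound 1 to compound 4 (0.03 log units; within the scatter) and is also within the scatter, so at this position all four compounds remain indistinguishable, whether the group carries an aromatic ring or not. Nothing measured here offers a reason for this flat result.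

Still open, going by these compounds, is whether an amine or a carboxylic acid on this nitrogen would move the number beyond the scatter. The same question stands for a longer chain in place of the acetyl of compound 4.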